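A few compounds are considered here, and "the series" means these few. Any claim that something is new, unique, unknown or untested is made for them only; others in the source may bear on it.

Working notes on the series, read in a functional assay on MDA-MB-231 cells (Homo sapiens) for antiproliferative activity, read by CCK-8 assay, with a stated time of 72 h; a higher number here means a weaker inhibitor, a lower number a stronger inhibitor. Within the data shown here, compound 1 (`Cc1cc(Nc2cc(N3CCN(C)CC3)nc(Nc3ccc(S(N)(=O)=O)cc3)n2)n[nH]1`) gives 1210 nM and compound 2 (`Cc1cc(Nc2cc(N3CCN(C)CC3)nc(Nc3cccc([N+](=O)[O-])c3)n2)n[nH]1`) gives 114 nM, so compound 2 holds the lower of the two numbers so far. Among the measured compounds shown here, the only measured step lies at the place now in question: an 11-fold lower number from compound 1 to compound 2 (1.03 log units; beyond the scatter), large and beyond the scatter, with 3-nitrophenyl in place of 4-sulfamoylphenyl. Compound 3 (`COc1ccc(Nc2nc(Nc3cc(C)[nH]n3)cc(N3CCN(C)CC3)n2)cc1`) changes that same place again: 4-methoxyphenyl in place of 3-nitrophenyl on a nitrogen on an aromatic ring. For the measured compounds named here, no measured compound carries 4-methoxyphenyl, so the one step shows that a change here can move the number far, but not where this group will fall. With compound 2 at 114 nM, the low end of the range so far, a moderate rise is expected rather than a further drop. The expected step is a 3.1-fold higher number from compound 2 to compound 3 (0.49 log units; beyond the scatter). For compound 3 the estimated value is 350 nM, with an expected range of 90 nM to 1400 nM.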

Compound 3, half-maximal inhibitory concentration: 243 nM
Estimate against measurement, compound 3: 1.4-fold (0.16 log units) above; low and high end bracket the measured number.
By their numbers in this assay, from the lowest: compound 2; then compound 3; then compound 1.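

In this assay this place on the nitrogen now carries three different aryl groups, and the numbers spread unevenly across them. Replacing 3-nitrophenyl with 4-methoxyphenyl gives a 2.1-fold higher number from compound 2 to compound 3 (0.33 log units; beyond the scatter), a modest rise, while methoxy in place of sulfamoyl gives a 5.0-fold lower number from compound 1 to compound 3 (0.70 log units; beyond the scatter), so the large cost of 4-sulfamoylphenyl is not shared by every replacement of 3-nitrophenyl. No data on hand explain this order of the three groups.

Each group differs from the others in both its substituent and where that substituent sits on the phenyl ring, so these two effects cannot be separated. As far as these compounds go, it remains open how an amine or a carboxylic acid in place of the nitro group would fall in this order, and whether the order holds with other changes to the shared core.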